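From Trifluoromethoxy to Prenyloxy on a Shared Core

The compounds below may be only part of what the source reports. "The series", "measured", "known", "first", "only" and "open" are said of these compounds alone.

Compound 1 `O=C(NNC(=O)C1CC1c1ccc(OC(F)(F)F)cc1)c1ccncc1`: 56000 nM
Compound 2 `O=C(NNC(=O)C1CC1c1ccc(OCC(F)(F)F)cc1)c1ccncc1`: 10000 nM

Of the compounds shown here, two have so far been measured in a functional assay on A549 cells (Homo sapiens) for inhibition, read by MTT assay, with a stated time of 72 h; a higher number here means a weaker inhibitor, a lower number a stronger inhibitor. Compound 1 gives 56000 nM, and compound 2 gives 10000 nM. Among the measured compounds shown here, of these two numbers compound 2 holds the lower one; the single measured step is a 5.6-fold lower number from compound 1 to compound 2 (0.75 log units; beyond the scatter), which lengthened the chain on the aromatic oxygen.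

Compound 3 `CC(C)=CCOc1ccc(C2CC2C(=O)NNC(=O)c2ccncc2)cc1` remains to be measured in this assay. It differs from compound 2 by 2-methylprop-1-en-1-yl in place of trifluoromethyl on a saturated chain carbon bound to an oxygen on an aromatic ring. For the measured compounds named here, only the step of a 5.6-fold lower number from compound 1 to compound 2 (0.75 log units; beyond the scatter) bears on this change, and it is the sole guide: it was modest and lowered the number. A second modest step downward, or none beyond the scatter, is therefore expected. Compound 3 is estimated at 5000 nM, in a range from 1500 nM to 20000 nM. The step this estimate implies is expected to be a 2.0-fold lower number from compound 2 to compound 3 (0.30 log units; within the scatter).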

Compound 3, half-maximal inhibitory concentration: > 100000 nM
Compound 3: a limit, no number; the forecaster's own chance of this, stated with the estimate: 10%; middle value at least 20-fold (1.30 log units) away from the limit.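

In this assay, the reading for compound 3 is a limit of the assay and not a number: the limit of > 100000 nM in this assay, at which 1 of the 3 values shown sits. Among the compounds shown here, at this position the number does not simply fall as the group on the oxygen grows: 2-methylprop-1-en-1-yl in place of trifluoromethyl on the saturated chain carbon gives an at least 10-fold higher number from compound 2 to compound 3 (1.00 log units; beyond the scatter), opposite in direction to the one earlier step. Set against the shorter trifluoromethoxy compound, the reading is an at least 1.7-fold higher number from compound 1 to compound 3 (0.25 log units; that floor lies within the scatter), so compound 3 cannot be ordered against compound 1.

The compounds shown leave open whether the double bond, the branching or the loss of fluorine accounts for the change. A saturated 3-methylbutyl chain or a plain ethyl group on the same oxygen would separate these readings.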